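Replacing 2,4-Dichlorophenyl with 4-Fluorophenyl on the Chain

The source may hold more compounds than are shown below. What is called first, only, known or untested is meant among the compounds shown, and "the series" means these compounds.

Measured so far in a functional assay on ACHN cells (Homo sapiens); a lower number here means a stronger inhibitor of growth, a higher number a weaker inhibitor of growth:
- Compound 1 `O=S(=O)(/C=C/c1ccc(Cl)cc1)Cc1ccc(Nc2ncnc3ccccc23)cc1`: > 100000 nM (a limit)
- Compound 2 `O=S(=O)(/C=C/c1ccc(F)cc1Cl)Cc1ccc(Nc2ncnc3cc(Cl)ccc23)cc1`: 17000 nM
- Compound 3 `COc1cc2ncnc(Nc3ccc(CS(=O)(=O)/C=C/c4ccc(Cl)cc4Cl)cc3)c2cc1OC`: 15000 nM

Compound 3 gives 15000 nM and compound 2 gives 17000 nM, so these two values lie within the usual scatter of each other. Compound 1 gives > 100000 nM, which is a limit of the assay and not a number.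

The next compound is compound 4 `COc1cc2ncnc(Nc3ccc(CS(=O)(=O)/C=C/c4ccc(F)cc4)cc3)c2cc1OC`, which keeps the core of compound 3. The difference is 4-fluorophenyl in place of 2,4-dichlorophenyl on a double-bonded chain carbon bound to a double-bonded chain carbon.

Within the data shown here, no measured pair of compounds shows this change alone, so any forecast for this assay is loose. Starting from compound 3 with 15000 nM, a modest move towards a higher number is expected, which would mean weaker growth inhibition. The expected change is a 1.7-fold higher number from compound 3 to compound 4 (0.22 log units; within the scatter), and this may not be much larger than the scatter. A result reported only as a limit also remains possible. Compound 4 is estimated to give 25000 nM, with an expected range of 9000 nM to 80000 nM.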

Compound 4, concentration for 50% growth inhibition: > 100000 nM
Compound 4: a limit, no number; the forecaster's own chance of this, stated with the estimate: 25%; at least 4.0-fold (0.60 log units) between middle value and limit.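

In this assay, 4-fluorophenyl in place of 2,4-dichlorophenyl on a double-bonded chain carbon bound to a double-bonded chain carbon gives an at least 6.6-fold higher number from compound 3 to compound 4 (0.82 log units; beyond the scatter). This is the first pair shown that differs in one place only, so it ties a loss of growth inhibition directly to the group at this position, with the core of compound 3 left unchanged. Compound 4 gives > 100000 nM, which is a limit of the assay and not a number, so the step can be read only as a minimum and its full size stays unknown: the limit of > 100000 nM in this assay, at which 2 of the 4 values shown sit.

The compounds shown do not separate the effect of losing the two chlorine atoms from that of gaining the fluorine atom, as this one change does both at once, and no cause for the loss can be drawn from these values. On these data alone, it also remains open how this position would respond to a phenyl ring carrying an amine or a carboxylic acid, and whether any such group could bring the number down.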